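This account rests on a few compounds, and the source may have more. Where it says the series, first, only, none or still open, it means among the compounds named here.

Measured so far in a functional assay on SNB-19 cells (Homo sapiens) for cytotoxicity, read by sulforhodamine B assay, with a stated time of 24 h; a lower number here means a stronger inhibitor of growth, a higher number a weaker inhibitor of growth:

compound 1 `COc1ccc(C(=O)/C=C/c2cc3ccccc3[nH]c2=O)cc1`: 19100 nM
compound 2 `O=C(/C=C/c1cc2ccccc2[nH]c1=O)c1ccc(O)cc1`: 18000 nM

Going by the values given here, compound 2 holds the lower of the two numbers, but its nearest neighbour is compound 1 and the only measured step, a 1.1-fold lower number from compound 1 to compound 2 (0.03 log units; within the scatter), lies within the scatter, so the two stand level on the shared core.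

Compound 3 `O=C(/C=C/c1cc2ccccc2[nH]c1=O)c1ccc(Cl)cc1` is the next member and is not yet measured. It differs from compound 2 in one place: chloro in place of hydroxy on an aromatic carbon.

Among the compounds with values here, only one measured step bears on this position, the change from compound 1 to compound 2, and it moved the number by a 1.1-fold lower number from compound 1 to compound 2 (0.03 log units; within the scatter), which is no real movement. Nothing measured here covers an exchange of hydroxy for chloro on this ring, so the expectation for compound 3 in this assay leans on the flatness seen so far and carries a wide range. Compound 3 is expected to land near compound 2, with a step of about a 1.2-fold lower number from compound 2 to compound 3 (0.08 log units; within the scatter), a change that would not exceed the scatter. The estimate for compound 3 is 15000 nM, within a range from 6000 nM to 40000 nM.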

Compound 3, concentration for total growth inhibition: > 100000 nM
Compound 3 ended at the assay's limit (the forecaster's own chance of this, stated with the estimate: 5%); middle value at least 6.6-fold (0.82 log units) from the limit.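

Compound 3 reaches the limit of this assay at > 100000 nM, and this value is a limit, not a number: the limit of > 100000 nM in this assay, at which 1 of the 3 values shown sits.

Unlike the exchange of methoxy for hydroxy, which left compound 1 and compound 2 level on the shared core, this position now shows that the group on the ring can matter in this assay. The change to chloro gives an at least 5.5-fold higher number from compound 2 to compound 3 (0.74 log units; beyond the scatter), and the comparison with the methoxy compound gives an at least 5.2-fold higher number from compound 1 to compound 3 (0.71 log units; beyond the scatter), so both steps lie beyond the scatter and the flatness seen earlier holds only for the pair of oxygen-linked groups.

Going by these compounds, the size of the loss stays open, since both steps rest on a limit and show only how large they are at the least. The three compounds also cannot separate the departure of oxygen from the arrival of chlorine, a question that a compound with an amine, a fluoro group or a plain methyl group at this place on the 4-substituted phenyl ring could address.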